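Amide aryl variation on the flavonol core

The compounds below may be only part of what the source reports. "The series", "measured", "known", "first", "only" and "open" are said of these compounds alone.

Three amides sharing one core are in hand. Compound 1 `Cc1cc(C(=O)Nc2cccc(-c3oc4cc(-c5ccc(F)cc5)ccc4c(=O)c3O)c2)ccc1F` gives 11500 nM in a functional assay on A549 cells (Homo sapiens) for antiproliferative activity, read by CCK-8 assay, with a stated time of 72 h; a lower number here means a stronger inhibitor, a higher number a weaker inhibitor. Compound 2 `O=C(Nc1cccc(-c2oc3cc(-c4ccc(F)cc4)ccc3c(=O)c2O)c1)c1cc(F)cc(F)c1` gives 7620 nM in this assay, and compound 3 `N#Cc1ccc(C(=O)Nc2cccc(-c3oc4cc(-c5ccc(F)cc5)ccc4c(=O)c3O)c2)cc1` gives 2360 nM in this assay. Compound 3 holds the lowest number of the three: the step of a 4.9-fold lower number from compound 1 to compound 3 (0.69 log units; beyond the scatter) and the step of a 3.2-fold lower number from compound 2 to compound 3 (0.51 log units; beyond the scatter) both lie beyond the scatter, while the step of a 1.5-fold lower number from compound 1 to compound 2 (0.18 log units; within the scatter) does not.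

Compound 4 `O=C(Nc1cccc(-c2oc3cc(-c4ccc(F)cc4)ccc3c(=O)c2O)c1)c1ccc([N+](=O)[O-])cc1` is the next member. Relative to compound 3 it carries nitro in place of cyano on an aromatic carbon. Within the data shown here, none of the measured steps exchanges one group for another on the same aromatic carbon of the amide aryl ring; the measured steps only show that changing the whole aryl group moves the number by a modest amount at most. With nothing closer to go on, the step is expected to be small, a 1.3-fold higher number from compound 3 to compound 4 (0.10 log units; within the scatter), with no firm direction. Compound 4 is therefore estimated at 3000 nM in this assay, within a range of 1000 nM to 9000 nM.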

Compound 4, half-maximal inhibitory concentration: 2440 nM
For compound 4 the middle estimate is 1.2-fold (0.09 log units) above the measured one; measured number inside the range.
By their numbers in this assay, from the lowest: compounds 3 and 4 (each within the scatter of the next); then compounds 2 and 1 (each within the scatter of the next).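

Among these compounds, on the aromatic carbon para to a large group, nitro in place of cyano (a 1.0-fold higher number from compound 3 to compound 4 (0.01 log units; within the scatter)) in this assay is the first exchange of one group for another at a single carbon of the amide aryl ring, and the two groups cannot be told apart here. Compound 4 keeps the separation already seen for compound 3 from the other two amides (a 3.1-fold lower number from compound 2 to compound 4 (0.49 log units; beyond the scatter); a 4.7-fold lower number from compound 1 to compound 4 (0.67 log units; beyond the scatter)), so 4-nitrophenyl and 4-cyanophenyl stand together, apart from 3,5-difluorophenyl and 4-fluoro-3-methylphenyl. Nothing on hand accounts for this result.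

As far as these compounds go, whether an amine or a carboxylic acid on the same carbon would stay with cyano and nitro remains open. The same question holds for a methoxy group there.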